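A few compounds are considered here, and "the series" means these few. Any claim that something is new, unique, unknown or untested is made for them only; others in the source may bear on it.

Working notes on the series. In a physicochemical assay for lipophilicity, using the shake flask method, in phosphate buffer, measured as octanol-water partition, with a stated time of 24 h, at pH 7.4, tested at 100 uM (on this read-out lower numbers stand for lower lipophilicity and higher numbers for higher lipophilicity), compound 2 (`Cc1cc(O)cc(C)c1-c1cccc(COc2ccc(OCC(=O)O)c(F)c2)c1`) gives 2.37, the higher of the two numbers available. Compound 3 (`Cc1cc(OCCCS(C)(=O)=O)ccc1-c1cccc(COc2ccc(OCC(=O)O)c(F)c2)c1`) gives 1.63, which is lower than compound 2 by more than the usual scatter. Compound 1 (`Cc1cc(OCc2cccc(-c3c(C)cc(OCCCS(C)(=O)=O)cc3C)c2)ccc1N(CC(=O)O)C(=O)c1ccccc1`) offers no comparison, as its entry reads "not determined" (no result reported).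

The next compound to be measured is compound 4 (`Cc1cc(OCCCO)cc(C)c1-c1cccc(COc2ccc(OCC(=O)O)c(F)c2)c1`). Its difference from compound 2 is 3-hydroxypropyl in place of hydrogen on an oxygen on an aromatic ring, so that hydroxy becomes 3-hydroxypropoxy.

Going by the values given here, no measured pair isolates this change, which leaves the expectation weakly anchored. Among the compounds with values here, compound 3, at 1.63, is the only measured compound with a chain on that oxygen, but it also differs from compound 2 elsewhere, so it serves only as a loose lower guide. A small downward move or none beyond the scatter is expected in this assay. The expected size of the move is a number 0.17 log units lower from compound 2 to compound 4 (within the scatter), which would not clearly separate the two compounds. For compound 4 the estimated value is 2.2, with an expected range from 1.8 to 2.6.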

Compound 4, distribution coefficient: 2.73
Compound 4: the middle estimate sits 0.53 log units below what was measured; the whole stated range lies below it.
By their numbers in this assay, from the lowest: compound 3; then compound 2; then compound 4.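

In this assay, going by these compounds alone, the change from hydroxy to 3-hydroxypropoxy gives a number 0.36 log units higher from compound 2 to compound 4 (beyond the scatter), the first step that isolates a single place. The oxygen on an aromatic ring therefore carries a chain here with the number rising rather than falling, although the entering 3-hydroxypropyl has a hydrogen-bond donor and a hydrogen-bond acceptor and brings no net charge. This is one step on one core, so it shows the direction and size of this change for compound 2 only, and no measurement shown accounts for that direction.

The compounds shown leave open whether the step follows from the terminal hydroxy or from the chain itself, a question that a 3-methoxypropyl, a plain propyl or a longer chain on the same oxygen could address. Also open, as far as these compounds go, is how a terminal amine or a terminal carboxylic acid on that chain would read in this assay, and whether the same change gives a similar step on a different core.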